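The source may hold more compounds than are shown below. What is called first, only, known or untested is meant among the compounds shown, and "the series" means these compounds.

Measured compounds

Compound 1, `O[C@@H]1[C@@H](OCc2ccccc2)[C@H](O)[C@@H](COCc2ccccc2)O[C@H]1Cc1ccccc1`, in a functional assay on HL-60 cells (Homo sapiens) for antiproliferative activity, read by MTT assay; a higher number here means a weaker inhibitor, a lower number a stronger inhibitor: 35300 nM
Compound 2, `O[C@@H]1[C@@H](OCc2ccccc2)[C@H](OCc2ccccc2)[C@@H](COCc2ccccc2)O[C@H]1Cc1ccccc1`, in this assay: 8700 nM
Compound 3, `OC[C@H]1O[C@@H](Cc2ccccc2)[C@H](O)[C@@H](O)[C@@H]1O`, in this assay: "not active" (no number reported)

Compound 1 and compound 2 share a core that carries several benzyl groups, and they differ in one place only: benzyl in place of hydrogen on an oxygen on a saturated carbon. That change brought a 4.1-fold lower number from compound 1 to compound 2 (0.61 log units; beyond the scatter). Compound 3 carries none of these benzyl ethers, and in this assay compound 3 gives "not active" (no number reported), so no number stands for it. Among the measured compounds shown here, compound 1 and compound 3 differ in more than one place; the difference between the two cores is not broken down here, and the two values show only that the fully benzylated compound 1 gives a number where compound 3 gives none.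

Compound 4, `OC[C@H]1O[C@@H](Cc2ccccc2)[C@H](O)[C@@H](O)[C@@H]1OCc1ccccc1`, has not yet been measured. It differs from compound 3 in the same way: benzyl in place of hydrogen on an oxygen on a saturated carbon. The place is described in the same words for both pairs, so this is the same kind of change on a different core.

In this assay the earlier step was a 4.1-fold lower number from compound 1 to compound 2 (0.61 log units; beyond the scatter), a modest gain. Starting from compound 3, which gives no number, a step of similar size is expected to bring compound 4 at most to the edge of what the assay reports. Compound 4 is therefore estimated at 70000 nM, with a wide range from 20000 nM to 250000 nM, and a real chance that only a limit is reported.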

Compound 4, half-maximal inhibitory concentration: "not active" (no number reported)
No number was reported for compound 4; there is nothing to compare the estimate with.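

In this assay compound 3 gives "not active" (no number reported) and compound 4 gives "not active" (no number reported) so no step can be read for hydroxy to benzyloxy between these two compounds. No other data bear on this result. The compounds shown leave open whether benzyl in this place changes antiproliferative activity at all on the core of compound 3.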